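A few compounds are considered here, and "the series" means these few. Any claim that something is new, unique, unknown or untested is made for them only; others in the source may bear on it.

Measured so far:
Compound 1, `CONC(=O)c1sc(-c2ccc(Cl)cc2)nc1C(Br)Br` — 81400 nM
Compound 2, `CCNC(=O)c1sc(-c2ccc(Cl)cc2)nc1C(Br)Br` — 33300 nM

In an ADME assay on BHK15 cells (Mesocricetus auratus) for inhibition, read by XTT assay, with a stated time of 36 h (on this read-out higher numbers stand for weaker inhibition of growth and lower numbers for stronger inhibition of growth), compound 1 holds the higher of the two numbers, and its nearest neighbour is compound 2, with a 2.4-fold lower number from compound 1 to compound 2 (0.39 log units; beyond the scatter). The unmeasured compound 3, `O=C(NC[C@@H](O)CO)c1sc(-c2ccc(Cl)cc2)nc1C(Br)Br`, departs from compound 1 at the same place: 2,3-dihydroxypropyl in place of methoxy on an amide-type nitrogen. Within the data shown here, the one measured step that bears on this change is a 2.4-fold lower number from compound 1 to compound 2 (0.39 log units; beyond the scatter), where one group on the amide-type nitrogen gave way to another and the number came down modestly. Compound 3 carries a 2,3-dihydroxypropyl on that nitrogen rather than the ethyl of compound 2, so the precedent is only partial, but the shared feature, the departure of the methoxy, points the same way. The step in this assay from compound 1 to compound 3 is therefore expected to be a modest one towards a lower number, roughly a 1.8-fold lower number from compound 1 to compound 3 (0.26 log units; within the scatter), with a real chance that it stays within the scatter. Compound 3 is estimated at 45000 nM, within a range from 15000 nM to 130000 nM.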

Compound 3, concentration for 50% growth inhibition: 158000 nM
Beside the measured number, compound 3's estimate is 3.5-fold (0.55 log units) below it; measured number outside the range, above it.
By their numbers in this assay, from the lowest: compound 2; then compounds 1 and 3 (each within the scatter of the next).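

In this assay, the swap of methoxy for 2,3-dihydroxypropyl on the amide-type nitrogen stays within the usual scatter (a 1.9-fold higher number from compound 1 to compound 3 (0.29 log units; within the scatter)), so the downward shift seen on leaving methoxy for ethyl does not carry over to every group placed there. The ethyl compound now stands apart from the new compound, and 1,2-dihydroxyethyl in place of methyl on the saturated chain carbon bound to that nitrogen gives a step beyond the scatter (a 4.7-fold higher number from compound 2 to compound 3 (0.68 log units; beyond the scatter)), which shows that extending the ethyl group in this way can be told apart on this read-out. Nothing available bears on what lies behind this difference.

The three compounds leave open how much of the step belongs to each hydroxyl, which a 2-hydroxyethyl group or a plain propyl chain on the same nitrogen would help to separate. They also leave open how the opposite configuration at the defined stereocentre would read, and whether an amine or a carboxylic acid at the end of the chain would sit with the ethyl compound or with the other two.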